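The compounds below may be only part of what the source reports. "The series", "measured", "known", "first", "only" and "open" are said of these compounds alone.

In an assay on isolated protein for inhibition of Monoglyceride lipase (Rattus norvegicus), read by fluorescence, with stated times of 15 min and 3 h (on this read-out higher numbers stand for weaker inhibition and lower numbers for stronger inhibition), the measured compounds are:
compound 1 `N#Cc1cccc(OC(=O)N2CCC(S(=O)(=O)C(c3ccccc3)c3ccccc3)CC2)c1`: 1000 nM
compound 2 `N#Cc1ccc(F)c(OC(=O)N2CCC(C(c3ccccc3)c3ccccc3)CC2)c1`: 112 nM
compound 3 `N#Cc1cccc(OC(=O)N2CCC(C(c3ccc(Cl)cc3)c3ccc(Cl)cc3)CC2)c1`: 32.5 nM

Compound 2 sits second highest of the three numbers: the nearest value is that of compound 3, lower by a margin beyond the scatter, and the furthest is that of compound 1, higher by a wider margin, also beyond the scatter. Compound 4 `N#Cc1cccc(OC(=O)N2CCC(C(c3ccccc3)c3ccccc3)CC2)n1` differs from compound 2 in one place: 6-cyanopyridin-2-yl in place of 5-cyano-2-fluorophenyl on an oxygen next to a carbonyl group. Among the compounds with values here, no single-change pair among the measured compounds resembles this exchange, so no step is available to guide the direction. The account therefore expects a step from compound 2 to compound 4 of a 1.3-fold higher number from compound 2 to compound 4 (0.13 log units; within the scatter), not clearly beyond the scatter in either direction. For compound 4 in this assay the estimate is 150 nM, within a range from 30 nM to 700 nM.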

Compound 4, half-maximal inhibitory concentration: 75.8 nM
For compound 4 the middle estimate is 2.0-fold (0.30 log units) above the measured one; low and high end bracket the measured number.
By their numbers in this assay, from the lowest: compound 3; then compounds 4 and 2 (each within the scatter of the next); then compound 1.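

In this assay the exchange of 5-cyano-2-fluorophenyl for 6-cyanopyridin-2-yl on an oxygen next to a carbonyl group gives a 1.5-fold lower number from compound 2 to compound 4 (0.17 log units; within the scatter) and stays within the scatter. Within the data shown here, this position therefore takes a ring with one hetero atom and no fluorine without a clear change in inhibition, whereas the earlier compounds carried only rings of carbon here. No evidence accounts for this result. The compounds shown leave open how an amine or a carboxylic acid in place of the nitrile on this ring would read.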